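The compounds below may be only part of what the source reports. "The series", "measured", "known", "first", "only" and "open" are said of these compounds alone.

The measured compounds in a functional assay on MV4-11 cells (Homo sapiens) for cytotoxicity, read by MTT assay, with a stated time of 72 h; on this read-out lower numbers stand for stronger inhibition and higher numbers for weaker inhibition:
compound 1 `CC(C)(C)c1cc(NC(=O)Nc2ccc(-c3cn4ccccc4n3)cc2)no1` gives 3.09 nM;
compound 2 `CC(C)(C)c1cc(NC(=O)Nc2ccc(-c3cn4ncccc4n3)cc2)no1` gives 59.1 nM;
compound 3 `CC(C)(C)c1cc(NC(=O)Nc2ccc(-c3cn4cc(Cl)ccc4n3)cc2)no1` gives 24.8 nM.

Compound 3 holds the second highest of these three numbers. The step of an 8.0-fold higher number from compound 1 to compound 3 (0.90 log units; beyond the scatter) separates it from compound 1, and compound 2 with 59.1 nM sits somewhat higher, by a gap that is beyond the scatter.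

Compound 4 `CC(C)(C)c1cc(NC(=O)Nc2ccc(-c3cn4cc(I)ccc4n3)cc2)no1` differs from compound 3 in one place: iodo in place of chloro on an aromatic carbon. Among the compounds with values here, no measured step exchanges one halogen for another, so nothing seen so far covers this change directly. The step that comes nearest is an 8.0-fold higher number from compound 1 to compound 3 (0.90 log units; beyond the scatter), where chloro took the place of hydrogen at this same carbon and the number rose by a modest amount. The step of a 19-fold higher number from compound 1 to compound 2 (1.28 log units; beyond the scatter), which rebuilt the six-membered ring of the shared core, does not concern this position and says nothing about iodo.

Within the data shown here, since the only evidence is that a halogen at this carbon costs some potency relative to hydrogen, and nothing shows whether a larger halogen costs more or less, compound 4 is expected to land close to compound 3, with the step of a 1.4-fold higher number from compound 3 to compound 4 (0.15 log units; within the scatter) estimated to stay within the scatter. Compound 4 is therefore estimated at 35 nM in this assay, in a range from 10 nM to 120 nM.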

Compound 4, half-maximal inhibitory concentration: 98.6 nM
The estimate for compound 4 lay 2.8-fold (0.45 log units) below the measured number; low and high end bracket the measured number.
By their numbers in this assay, from the lowest: compound 1; then compound 3; then compounds 2 and 4 (each within the scatter of the next).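

In this assay, within the data shown here, the choice of halogen at this carbon matters: a 4.0-fold higher number from compound 3 to compound 4 (0.60 log units; beyond the scatter) is a change beyond the scatter, which the earlier compounds could not show, as they carried only hydrogen or chloro here. The cost of replacing hydrogen also differs between the two halogens, with a 32-fold higher number from compound 1 to compound 4 (1.50 log units; beyond the scatter) counting as a large step while an 8.0-fold higher number from compound 1 to compound 3 (0.90 log units; beyond the scatter) counts as a modest one. Among these three compounds, which differ only at this carbon, the number therefore rises from hydrogen through chloro to iodo, though nothing available gives a reason for this order.

As far as these compounds go, two halogens are too few to define a trend, so it remains open whether fluoro or bromo at this carbon would follow the same order, or whether a non-halogen group such as methoxy or an amine would fare better or worse than chloro and iodo. It is equally open whether the order holds at the other carbons of this six-membered ring, since all the substituents shown here sit at this single carbon.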